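The source may report more compounds than this note shows. Statements on the series, on what has been measured and on what is new or still open speak of the compounds shown alone.

Working notes on the series. Compound 3 `CCN(CC)S(=O)(=O)c1ccc(S(=O)(=O)N2CCC[C@@H](C(=O)NC3CN(C(=O)OC(C)(C)C)C3)C2)cc1` carries a tert-butoxycarbonyl on the azetidine nitrogen; in a functional assay on MIA PaCa-2 cells (Homo sapiens) for inhibition, read by MTT assay, with a stated time of 3 days (on this read-out lower numbers stand for stronger inhibition and higher numbers for weaker inhibition), compound 3 gives > 10000 nM, which is a limit of the assay and not a number. Its two neighbours are compound 1 `CCN(CC)S(=O)(=O)c1ccc(S(=O)(=O)N2CCC[C@@H](C(=O)NC3CN(C(=O)C4CC4)C3)C2)cc1` and compound 2 `CCN1CC(NC(=O)[C@@H]2CCCN(S(=O)(=O)c3ccc(S(=O)(=O)N(CC)CC)cc3)C2)C1`. In this assay compound 1 gives > 10000 nM, again a limit. In this assay compound 2 gives > 10000 nM, also a limit. The three steps among them, a step that the two limits leave unreadable from compound 1 to compound 2, a step that the two limits leave unreadable from compound 1 to compound 3 and a step that the two limits leave unreadable from compound 2 to compound 3, are therefore of unreadable size, since (the limit of > 10000 nM in this assay, at which 3 of the 3 values shown sit). The change now followed, (4-(3-methyl-1,2,4-oxadiazol-5-yl)piperazin-1-yl in place of (1-(tert-butoxycarbonyl)azetidin-3-yl)amino on a carbonyl carbon), gives compound 4 `CCN(CC)S(=O)(=O)c1ccc(S(=O)(=O)N2CCC[C@@H](C(=O)N3CCN(c4nc(C)no4)CC3)C2)cc1`. Going by the values given here, none of the measured steps reads on this change, and every value so far sits at the limit, so no direction can be drawn from them. The expectation for compound 4 in this assay is accordingly a step that the limit leaves unreadable from compound 3 to compound 4 that stays near the limit, with a wide range. The estimate for compound 4 is 12000 nM, between 2000 nM and 60000 nM.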

Compound 4, half-maximal inhibitory concentration: > 10000 nM
Compound 4: only a limit was reported (the forecaster's own chance of this, stated with the estimate: 70%); the middle value does not contradict the limit.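

In this assay, the steps to compound 4 from compound 1, compound 2 and compound 3 cannot be read, and no new step follows: the limit of > 10000 nM in this assay, at which 4 of the 4 values shown sit.

The compounds shown leave open whether any of these groups on the carbonyl carbon gives a readable value, and how the groups rank.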